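The source may hold more compounds than are shown below. What is called first, only, known or untested is meant among the compounds shown, and "the series" means these compounds.

Measured compounds in a functional assay on CHO cells for agonist activity at Glucose-dependent insulinotropic receptor (Homo sapiens), read by a luciferase reporter and cAMP accumulation, with a stated time of 2 h; a lower number here means that less compound is needed, a higher number that more compound is needed for the effect:

Compound 1 `CC(C)(C)OC(=O)N1CCC(CCOC(=O)N2CCc3cc(S(C)(=O)=O)ccc32)CC1`: 68 nM
Compound 2 `CC(COC(=O)N1CCc2cc(S(C)(=O)=O)ccc21)C1CCN(C(=O)OC(C)(C)C)CC1`: 8.4 nM

Compound 1 stands highest of the two numbers in this assay; the nearest is compound 2, reached by an 8.1-fold lower number from compound 1 to compound 2 (0.91 log units; beyond the scatter). That step changes a saturated chain carbon and touches nothing on the aromatic part of the shared core.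

Compound 3 `CC(C)(C)OC(=O)N1CCC(CCOC(=O)N2CCc3c2ccc(S(C)(=O)=O)c3Cl)CC1` is the next analogue, still to be measured in this assay. Relative to compound 1 it carries chloro in place of hydrogen on an aromatic carbon, set ortho to the methylsulfonyl group and ortho to the fused ring.

Among the measured compounds shown here, no measured step bears on this change. For the measured compounds named here, the one step in hand, from compound 1 to compound 2, concerns a methyl on the chain and says nothing about substitution on the aromatic ring. Going by the values given here, with no aromatic-ring analogue to compare, the direction of the step in this assay is open; a change beyond the scatter in either sense cannot be ruled out, nor can none.

The working expectation for compound 3 in this assay is therefore a number near that of compound 1, estimated at 50 nM with a wide range of 10 nM to 250 nM. This estimate corresponds to a step of a 1.4-fold lower number from compound 1 to compound 3 (0.13 log units; within the scatter), to be revised once the measurement arrives.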

Compound 3, half-maximal effective concentration: 530 nM
Compound 3: middle estimate off by 11-fold (1.03 log units), on the low side; the measured number lies above the stated range.
By their numbers in this assay, from the lowest: compound 2; then compound 1; then compound 3.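

In this assay, chloro in place of hydrogen on the aromatic carbon ortho to the methylsulfonyl group gives a 7.8-fold higher number from compound 1 to compound 3 (0.89 log units; beyond the scatter) and so shows that this position of the shared core is sensitive to substitution, which the chain step could not reveal. The change moves the number in the opposite direction to the chain methyl, which gives an 8.1-fold lower number from compound 1 to compound 2 (0.91 log units; beyond the scatter) in the same assay, so the compounds shown now contain one change on the chain that lowers the number and one on the aromatic ring that raises it, each read only from compound 1. Nothing available explains the higher number with chloro at this position.

On these data alone, whether the rise belongs to chloro in particular or would follow any replacement of hydrogen at this carbon stays open, and fluoro, methyl or methoxy at the same place would separate those two readings. The compounds shown also do not tell whether the chloro step and the chain methyl step would hold when both changes stand in one molecule.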